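Notes on compound 4 in the cytotoxicity series

This account rests on a few compounds, and the source may have more. Where it says the series, first, only, none or still open, it means among the compounds named here.

Measured so far:
compound 1, `CCN1C(=O)S/C(=C\c2ccc(N)cc2)C1=O`: 91000 nM
compound 2, `Nc1cccc(/C=C2\SC(=O)N(Cc3ccc(F)cc3)C2=O)c1`: 87000 nM
compound 3, `Nc1cccc(/C=C2\SC(=O)N(Cc3cccc(Cl)c3)C2=O)c1`: 195000 nM

All three numbers come from a functional assay on CCRF-CEM cells (Homo sapiens) for cytotoxicity, read by cell counting, with a stated time of 3 days; a lower number here means a stronger inhibitor, a higher number a weaker inhibitor. Compound 3 holds the highest number of the three; compound 1 stands nearest to it and compound 2 furthest, both with lower numbers. Going by the values given here, the only step between two compounds that differ in one place is a 2.2-fold higher number from compound 2 to compound 3 (0.35 log units; beyond the scatter), and it concerns the group on the ring nitrogen, not the aminophenyl.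

Compound 4 is `Nc1ccc(/C=C2\SC(=O)N(Cc3cccc(Cl)c3)C2=O)cc1`. The change from compound 3 is 4-aminophenyl in place of 3-aminophenyl on a double-bonded chain carbon bound to a double-bonded ring carbon. Among the compounds with values here, no measured pair isolates this change. Compound 1 carries the 4-aminophenyl, but it also carries a different group on the ring nitrogen, so its value against compound 3 shows two differences together and cannot be read as one. Within the data shown here, the single known step does not bear on the aminophenyl. With nothing to point either way, the expectation for compound 4 in this assay is a step of no more than the usual scatter, written as a 1.3-fold lower number from compound 3 to compound 4 (0.11 log units; within the scatter). Compound 4 is therefore estimated at 150000 nM, with a range from 60000 nM to 400000 nM.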

Compound 4, half-maximal inhibitory concentration: 18000 nM
Estimate against measurement, compound 4: 8.3-fold (0.92 log units) above; the measured number lies below the stated range.
By their numbers in this assay, from the lowest: compound 4; then compounds 2 and 1 (each within the scatter of the next); then compound 3.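

In this assay, going by these compounds alone, the placing of 4-aminophenyl in place of 3-aminophenyl, on a double-bonded chain carbon bound to a double-bonded ring carbon, gives an 11-fold lower number from compound 3 to compound 4 (1.03 log units; beyond the scatter) even though the two groups have the same atoms, joined differently, so this place responds strongly to how the aminophenyl is joined, which no earlier pair could show. Within the data shown here, with the 4-aminophenyl held fixed, 3-chlorophenyl in place of methyl on a saturated chain carbon bound to an amide-type nitrogen in a ring gives a 5.1-fold lower number from compound 1 to compound 4 (0.70 log units; beyond the scatter) and is the first reading of the group on the ring nitrogen alongside this aminophenyl, showing that this second place also moves the number, by a smaller step than the aminophenyl change. No supporting measurement accounts for either step.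

As far as these compounds go, it remains open whether the 4-aminophenyl keeps its advantage when the group on the ring nitrogen carries 4-fluorophenyl, the group of compound 2. It also remains open whether the amine itself matters, since the compounds shown hold no hydroxyl or carboxylic acid in its place on the phenyl ring.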